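The compounds below may be only part of what the source reports. "The series", "measured", "known", "first", "only" and "open" are said of these compounds alone.

Working notes on the series. Compound 1 `O=C(Nc1nc2ccc(F)cc2s1)c1cn(-c2ccccc2)nc1-c1ccccc1` gives in a functional assay on U-87MG ATCC cells for cytotoxicity against U-87 MG (Homo sapiens), read by MTT assay, with a stated time of 72 h (a lower number here means a stronger inhibitor, a higher number a weaker inhibitor), a value of 5570 nM. Compound 2 `O=C(Nc1nc2ccc(F)cc2s1)c1cn(-c2ccccc2)nc1-c1ccc(F)cc1` gives 12500 nM, and compound 3 `O=C(Nc1nc2ccccc2s1)c1cn(-c2ccccc2)nc1-c1ccc(Cl)cc1` gives 11500 nM. Among these three numbers compound 3 stands second highest: its value against compound 2 lies within the scatter, while against compound 1 its number is higher and beyond the scatter.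

Compound 4 `O=C(Nc1nc2ccc(F)cc2s1)c1cn(-c2ccccc2)nc1-c1ccc(Cl)cc1` differs from compound 3 by fluoro in place of hydrogen on an aromatic carbon. Within the data shown here, no measured pair differs at that position alone, so there is no direct precedent. Among the measured compounds shown here, the only step of the same kind, fluoro in place of hydrogen on an aromatic carbon, sits on a different ring and reads a 2.2-fold higher number from compound 1 to compound 2 (0.35 log units; beyond the scatter), a modest move towards a weaker inhibitor. On that basis the change is expected to be small, a 1.2-fold higher number from compound 3 to compound 4 (0.09 log units; within the scatter), with a higher number thought somewhat more likely than a lower one. The expected value for compound 4 in this assay is 14000 nM, within a range from 5000 nM to 35000 nM.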

Compound 4, half-maximal inhibitory concentration: 7770 nM
Estimate against measurement, compound 4: 1.8-fold (0.26 log units) above; the range from low to high includes it.
By their numbers in this assay, from the lowest: compounds 1, 4, 3 and 2 (each within the scatter of the next, the first and the last beyond it).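

On the ring of the 1,3-benzothiazol-2-yl group, fluoro in place of hydrogen gives in this assay a 1.5-fold lower number from compound 3 to compound 4 (0.17 log units; within the scatter) and so leaves the reading of the chloro compound without a step beyond the scatter. With 6-fluoro-1,3-benzothiazol-2-yl held constant, chloro also stays within the scatter of both neighbours, with a 1.6-fold lower number from compound 2 to compound 4 (0.21 log units; within the scatter) and a 1.4-fold higher number from compound 1 to compound 4 (0.14 log units; within the scatter), although compound 1 and compound 2 themselves lie beyond the scatter of each other. One fluoro-for-hydrogen step therefore does not predict the other when the place and core differ: the same change on two cores in this assay, a 2.2-fold higher number (0.35 log units; beyond the scatter) from compound 1 to compound 2 and a 1.5-fold lower number (0.17 log units; within the scatter) from compound 3 to compound 4, 3.3-fold (0.52 log units) apart, beyond the scatter of two such steps.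

Among these compounds, only one pair tests this fluoro, so its reading with hydrogen or fluoro on the other ring stays open. Going by these compounds, whether an amine or a carboxylic acid at the same position would be tolerated also stays open.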